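Working notes: from compound 3 to compound 4

This account rests on a few compounds, and the source may have more. Where it says the series, first, only, none or still open, it means among the compounds named here.

Values in a functional assay on HeLa cells (Homo sapiens) for antiproliferative activity, read by MTT assay, with a stated time of 72 h; on this read-out lower numbers stand for stronger inhibition and higher numbers for weaker inhibition:
- Compound 1 `C/C=C/C(=O)Nc1cccc(Oc2nc(Nc3ccn(C)n3)nc3c2CSCC3)c1`: > 50000 nM (a limit)
- Compound 2 `C/C=C/C(=O)Nc1cccc(Oc2nc(Nc3cccc(OC)c3)nc3c2CSCC3)c1`: 13800 nM
- Compound 3 `C=CC(=O)Nc1cccc(Oc2nc(Nc3cccc(C#N)c3)nc3c2CSCC3)c1`: 34900 nM

Compound 3, at 34900 nM, holds the higher of the two actual numbers. The value of compound 1 is a limit. Compound 4 `C/C=C/C(=O)Nc1cccc(Oc2nc(Nc3cccc(C#N)c3)nc3c2CSCC3)c1` differs from compound 3 as follows: prop-1-en-1-yl in place of vinyl on a carbonyl carbon. For the measured compounds named here, the only measured step, an at least 3.6-fold lower number from compound 1 to compound 2 (0.55 log units; beyond the scatter), lies at a different place, and no measured step makes this exchange. No step beyond the scatter is therefore expected in this assay, and no direction is favoured. The expected step is a 1.2-fold lower number from compound 3 to compound 4 (0.07 log units; within the scatter). Compound 4 is estimated at 30000 nM, with an expected range of 13000 nM to 50000 nM.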

Compound 4, half-maximal inhibitory concentration: 12800 nM
Compound 4: the middle estimate sits 2.3-fold (0.37 log units) above what was measured; measured number below the stated range.
By their numbers in this assay, from the lowest: compounds 4 and 2 (each within the scatter of the next); then compound 3. At a limit, above all of these: compound 1.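

In this assay, the place on the carbonyl carbon responds to a small exchange: prop-1-en-1-yl in place of vinyl gives a 2.7-fold lower number from compound 3 to compound 4 (0.44 log units; beyond the scatter). With prop-1-en-1-yl in that place, cyano in place of methoxy on an aromatic carbon gives a 1.1-fold lower number from compound 2 to compound 4 (0.03 log units; within the scatter), so this exchange does not separate the two compounds. The exchange of 3-cyanophenyl for 1-methyl-1H-pyrazol-3-yl gives an at least 3.9-fold lower number from compound 1 to compound 4 (0.59 log units; beyond the scatter), and its size rests on a limit: the limit of > 50000 nM in this assay, at which 1 of the 4 values shown sits.

From the compounds shown here alone, whether a longer chain or an amine on that carbonyl side chain extends the step stays open. So does whether the step recurs with other groups on the aromatic ring.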